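Swapping the azole on the branched carbon

The compounds below may be only part of what the source reports. "The series", "measured", "known", "first", "only" and "open" are said of these compounds alone.

Measured so far in an assay on CHO cells for displacement of a labelled ligand from prostaglandin E2 receptor EP3 subtype (Homo sapiens), read by radioligand binding; on this read-out higher numbers stand for weaker inhibition and lower numbers for stronger inhibition:
compound 1 `CC(C)C(c1ccc(-c2ccc3cccc(F)c3c2)[nH]c1=O)N1CCCCS1(=O)=O` — 14 nM
compound 2 `CC(C)C(Cc1nnc[nH]1)c1ccc(-c2ccc3cccc(F)c3c2)[nH]c1=O` — 10 nM
compound 3 `CC(C)C(c1nnc[nH]1)c1ccc(-c2ccc3cccc(F)c3c2)[nH]c1=O` — 12 nM

Compound 3 stands second highest of the three, with compound 1 as its nearest neighbour (a 1.2-fold lower number from compound 1 to compound 3 (0.07 log units; within the scatter)) and compound 2 as its furthest (a 1.2-fold higher number from compound 2 to compound 3 (0.08 log units; within the scatter)); all three sit within the scatter of one another. Compound 4 `CC(C)C(c1noc(=O)[nH]1)c1ccc(-c2ccc3cccc(F)c3c2)[nH]c1=O` differs from compound 3 by a group of 6 heavy atoms (2 carbon, 2 nitrogen, 2 oxygen; one five-membered aromatic ring with 3 hetero atoms) in place of a group of 5 heavy atoms (2 carbon, 3 nitrogen; one five-membered aromatic ring with 3 hetero atoms), on a saturated chain carbon bound to an aromatic carbon and a saturated chain carbon. Among the compounds with values here, the steps that bear on this position, a 1.4-fold lower number from compound 1 to compound 2 (0.15 log units; within the scatter) and a 1.2-fold lower number from compound 1 to compound 3 (0.07 log units; within the scatter), both exchanged a group at the same carbon and stayed within the scatter. Compound 4 is therefore expected to show no step beyond the scatter in this assay, a 1.1-fold higher number from compound 3 to compound 4 (0.03 log units; within the scatter). For compound 4 the estimate is 13 nM, ranging from 5 nM to 35 nM.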

Compound 4, inhibition constant: 15 nM
Estimate against measurement, compound 4: 1.2-fold (0.06 log units) below; the range from low to high includes it.
By their numbers in this assay, from the lowest: compounds 2, 3, 1 and 4 (each within the scatter of the next).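

In this assay the exchange of 4H-1,2,4-triazol-3-yl for a ring of two carbons, two nitrogens and two oxygens gave a 1.3-fold higher number from compound 3 to compound 4 (0.10 log units; within the scatter) on this saturated chain carbon. The other comparisons, a 1.5-fold higher number from compound 2 to compound 4 (0.18 log units; within the scatter) and a 1.1-fold higher number from compound 1 to compound 4 (0.03 log units; within the scatter) in turn, also stayed within the scatter. This position therefore accepted a ring carrying oxygen and a double bond outside the aromatic ring with no readable change from the triazole-bearing compounds or the compound with the six-membered ring. On these data alone, whether a carboxylic acid or an amine at this carbon would also stay within the scatter remains open. Nothing measured here accounts for these steps.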